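From Hydroxy to Ethylamino on a Shared Core

The source may report more compounds than this note shows. Statements on the series, on what has been measured and on what is new or still open speak of the compounds shown alone.

In a functional assay on A2780 cells (Homo sapiens) for antiproliferative activity, read by MTT assay, with a stated time of 48 h (on this read-out lower numbers stand for stronger inhibition and higher numbers for weaker inhibition), three compounds have been measured so far. Compound 1 `COc1ccc(C(=O)c2ccc(OC)c3c2C=CC(C)(C)O3)c(NC(=O)CO)c1` gives 420 nM, the lowest number of the three. Compound 2 `CNCC(=O)Nc1cc(OC)ccc1C(=O)c1ccc2c(c1)C=CC(C)(C)O2` gives 850 nM, and compound 3 `CCNCC(=O)Nc1cc(OC)ccc1C(=O)c1ccc(OC)c2c1OC(C)(C)C=C2` gives 1980 nM. Both lie beyond the scatter from compound 1.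

Compound 4 `CCNCC(=O)Nc1cc(OC)ccc1C(=O)c1ccc(OC)c2c1C=CC(C)(C)O2` has not yet been measured. It keeps the core of compound 1 and changes one group: ethylamino in place of hydroxy on a saturated chain carbon bound to a carbonyl carbon. This places ethylamino in place of hydroxy on a saturated chain carbon bound to a carbonyl carbon. Within the data shown here, no measured pair isolates this change, so the evidence is indirect. The nearest guide is compound 3, which also carries ethylamino, on a different core, and gives 1980 nM. In this assay a step towards weaker inhibition is therefore expected, estimated as a 2.6-fold higher number from compound 1 to compound 4 (0.42 log units; beyond the scatter). Compound 4 is expected at 1100 nM, with an estimated range of 400 nM to 3000 nM.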

Compound 4, half-maximal inhibitory concentration: 4090 nM
For compound 4 the middle estimate is 3.7-fold (0.57 log units) below the measured one, and the stated range ends below it.
By their numbers in this assay, from the lowest: compound 1; then compound 2; then compound 3; then compound 4.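

Measured in this assay with the core of compound 1 held fixed, ethylamino in place of hydroxy on a saturated chain carbon bound to a carbonyl carbon brings a 9.7-fold higher number from compound 1 to compound 4 (0.99 log units; beyond the scatter) and so gives this position its first direct reading. The earlier compounds shown here could not show this, as none of them shared a core with compound 1, whereas this pair ties the move towards weaker inhibition to this one change. Nothing given here explains the step.

From the compounds shown here alone, whether a plain amino group, a carboxylic acid or a longer chain at this place would read closer to hydroxy or to ethylamino remains open. Also open is whether the same change would have a similar size on the cores of compound 2 and compound 3, where no hydroxy partner is shown.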